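Rearranging the Phenyl Group of Compound 2

The source may hold more compounds than are shown below. What is called first, only, known or untested is meant among the compounds shown, and "the series" means these compounds.

In a functional assay on KB cells (Homo sapiens) for antiproliferative activity, read by sulforhodamine B assay, with a stated time of 3 days (on this read-out higher numbers stand for an effect only at larger amounts of compound and lower numbers for an effect already at smaller amounts), compound 1 `CCC1=C(O)c2c(oc(-c3ccccc3F)cc2=O)C(CC)(CC)C1=O` reaches only a limit, > 56.2 uM. Going by the values given here, compound 2 `CCC1=C(O)c2c(oc(-c3ccc(OC)c(C)c3)cc2=O)C(CC)(CC)C1=O` gives 28.5 uM, the only true number so far. Compound 3 `CCC1=C(O)c2c(oc(-c3ccc(O)c(C)c3C)cc2=O)C(CC)(CC)C1=O` has the same atoms joined differently: 4-hydroxy-2,3-dimethylphenyl in place of 4-methoxy-3-methylphenyl on an aromatic carbon. Among the compounds with values here, the one measured step, an at least 1.9-fold lower number from compound 1 to compound 2 (0.29 log units; that floor lies within the scatter), exchanges a different group, and its floor lies within the scatter, so it suggests no direction for this change. The expected step is therefore none beyond the scatter: a 1.1-fold lower number from compound 2 to compound 3 (0.06 log units; within the scatter). For compound 3 the estimated value is 25 uM, with an expected range from 8 uM to 60 uM.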

Compound 3, concentration for half-maximal effect: 6.5 uM
Compound 3: middle estimate off by 3.8-fold (0.59 log units), on the high side; the measured number lies below the stated range.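

Swapping 4-methoxy-3-methylphenyl for 4-hydroxy-2,3-dimethylphenyl, with the same atoms rearranged, gives the first step at this position with true numbers at both ends and a size beyond the scatter: a 4.4-fold lower number from compound 2 to compound 3 (0.64 log units; beyond the scatter). Replacing 2-fluorophenyl with the same group gives an at least 8.6-fold lower number from compound 1 to compound 3 (0.93 log units; beyond the scatter), and this size is only a floor. Compound 1 has no true number, only a limit: the limit of > 56.2 uM in this assay, at which 1 of the 3 values shown sits.

As far as these compounds go, the change from compound 2 to compound 3 swaps methoxy for hydroxy and adds a methyl at once, and the share of each stays open. From the compounds shown here alone, whether an amine or a carboxylic acid in place of the hydroxy would keep this effect is also open.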